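The source may hold more compounds than are shown below. What is called first, only, known or untested is meant among the compounds shown, and "the series" means these compounds.

Compound 1 `CCCCOC(=O)CNC(=O)[C@H](CSc1ccc([N+](=O)[O-])cc1[N+](=O)[O-])NC(=O)CC[C@H](NC(=O)CC(C)C)C(=O)OCCCC`: 59.6 uM
Compound 2 `CCCCOC(=O)CNC(=O)[C@H](CSc1ccc([N+](=O)[O-])cc1[N+](=O)[O-])NC(=O)CC[C@H](NC(C)=O)C(=O)OCCCC`: > 300 uM

Two measured compounds frame the question. In a toxicity assay on KB cells (Homo sapiens) for cytotoxicity, read by fluorescence, with a stated time of 3 days (a higher number here means that more compound is needed for the effect, a lower number that less compound is needed), compound 1 gives 59.6 uM. For compound 2 the assay reports only a limit, > 300 uM, so no exact number is known. For the measured compounds named here, the single measured step is an at least 5.0-fold higher number from compound 1 to compound 2 (0.70 log units; beyond the scatter); its true size is known only as a lower bound because the limit of > 300 uM in this assay, at which 1 of the 2 values shown sits, fixes where one of the two values sits. Compound 2 therefore stands at the weak end of what has been seen so far. Compound 3 `CCCCOC(=O)CNC(=O)[C@H](CSc1ccc([N+](=O)[O-])cc1[N+](=O)[O-])NC(=O)CC[C@H](NC(=O)CCc1ccccc1)C(=O)OCCCC` is not yet measured; it differs from compound 2 by benzyl in place of hydrogen on a saturated chain carbon bound to a carbonyl carbon. This change runs counter to the measured step, with a benzyl group entering where hydrogen had replaced isopropyl, so a lower number in this assay is expected, of about the size an at least 6.0-fold lower number from compound 2 to compound 3 (0.77 log units; beyond the scatter). Compound 3 is estimated at 50 uM, within 15 uM to 200 uM.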

Compound 3, concentration for half-maximal effect: > 300 uM
Compound 3: a limit, no number; the forecaster's own chance of this, stated with the estimate: 25%; middle value at least 6.0-fold (0.77 log units) away from the limit.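

In this assay compound 3 gives > 300 uM, which is a limit of the assay and not a number. Benzyl in place of isopropyl on this saturated chain carbon bound to a carbonyl carbon gives an at least 5.0-fold higher number from compound 1 to compound 3 (0.70 log units; beyond the scatter), so adding carbon at this place does not by itself bring the number down, and of the three compounds only the one with isopropyl gives an exact value. The step from hydrogen to benzyl cannot be read, as both ends of it are limits.

From the compounds shown here alone, how far compound 2 and compound 3 really lie beyond the limit stays unknown. Going by these compounds, it also stays open whether the exact value of compound 1 is special to isopropyl, or whether a straight butyl chain, an amine or a carboxylic acid at this place would also give one.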